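The source may hold more compounds than are shown below. What is called first, only, known or untested is meant among the compounds shown, and "the series" means these compounds.

Measured compounds and their values in a functional assay on the whole organism (strain Wistar) for inhibition, with Rattus norvegicus as the target, read by paw edema, with stated times of 30 min and 60 min, at a dose of 50 mg/kg by the oral route; on this read-out lower numbers stand for less inhibition and higher numbers for more inhibition at the one dose given (going by the name of the read-out):

compound 1 `Cc1ccc(C2=NN(c3ccc([N+](=O)[O-])cc3)C(c3cn(-c4ccccc4)nc3-c3ccc(Cl)c(Cl)c3)C2)cc1`: 72.5%
compound 2 `CCC(=O)N1N=C(c2ccc(C)cc2)CC1c1cn(-c2ccccc2)nc1-c1ccc(Cl)c(Cl)c1`: 61.1%
compound 3 `CCC(=O)N1N=C(c2ccc(F)cc2)CC1c1cn(-c2ccccc2)nc1-c1ccc(Cl)c(Cl)c1`: 63.4%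

Compound 2 stands lowest of the three numbers, though its gap to compound 3 is within the scatter and only its gap to compound 1 lies beyond it. The next compound, compound 4 `Cc1ccc(C2=NNC(c3cn(-c4ccccc4)nc3-c3ccc(Cl)c(Cl)c3)C2)cc1`, has not yet been tested in this assay. Relative to compound 2 the change is hydrogen in place of propanoyl on an amine nitrogen in a ring: the propanoyl group leaves and only a hydrogen remains on that ring nitrogen. Among the compounds with values here, one measured step touches the same nitrogen: a number 11.4 percentage points lower from compound 1 to compound 2 (beyond the scatter), a modest loss when propanoyl took the place of 4-nitrophenyl. The step of a number 2.3 percentage points higher from compound 2 to compound 3 (within the scatter) concerns a different position and is within the scatter. Within the data shown here, no measured pair shows what a bare hydrogen does at this nitrogen, so the expectation is uncertain. A small step, estimated as a number 4.1 percentage points lower from compound 2 to compound 4 (within the scatter), is expected for compound 4, likely within the scatter. Compound 4 is thus estimated at 57%, with a range from 44% to 70%.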

Compound 4, a percentage reported as inhibition, in the whole organism at one dose (the size of the read-out at that dose, not a potency): 56.5%
The estimate for compound 4 lay 0.5 percentage points above the measured number, within the range that was stated.
By their numbers in this assay, from the lowest: compounds 4, 2, 3 and 1 (each within the scatter of the next, the first and the last beyond it).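

In this assay, the ring nitrogen carrying only a hydrogen can now be compared directly with its acylated partner, and the result is a number 4.6 percentage points lower from compound 2 to compound 4 (within the scatter), so the propanoyl group cannot be told apart from a hydrogen here. The 4-nitrophenyl group can be told apart from hydrogen, with a number 16 percentage points lower from compound 1 to compound 4 (beyond the scatter), yet compound 4 still gives 56.5%, so much of the inhibition at this dose remains with no group on that nitrogen beyond a hydrogen. Nothing available explains either step.

Going by these compounds, whether the higher number with 4-nitrophenyl needs the nitro group, or would also come with a plain phenyl or a 4-methoxyphenyl on this nitrogen, remains open. Also open, on these data alone, is whether a benzoyl group or a longer acyl chain would stay level with hydrogen, as propanoyl does.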